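A small heteroaryl amide in a weakly active series

A few compounds are considered here, and "the series" means these few. Any claim that something is new, unique, unknown or untested is made for them only; others in the source may bear on it.

Measured in a functional assay on A549 cells (Homo sapiens) for antiproliferative activity, read by MTT assay, with a stated time of 72 h; a lower number here means a stronger inhibitor, a higher number a weaker inhibitor:
compound 1 `O=C(Nc1ccc(Cl)c(-c2nnc3c(Cl)cccn23)c1)c1ccccn1` gives only the assay's limit, > 100000 nM;
compound 2 `O=C(Nc1ccc(Cl)c(-c2nnc3c(Cl)cccn23)c1)c1cccc(Cl)c1` gives 52700 nM;
compound 3 `Cc1cc(Cl)ccc1C(=O)Nc1ccc(Cl)c(-c2nnc3c(Cl)cccn23)c1` gives only the assay's limit, > 100000 nM.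

Compound 3 thus sits at the limit of > 100000 nM in this assay, at which 2 of the 3 values shown sit. Compound 4 `O=C(Nc1ccc(Cl)c(-c2nnc3c(Cl)cccn23)c1)c1ccon1` differs from compound 3 by 1,2-oxazol-3-yl in place of 4-chloro-2-methylphenyl on a carbonyl carbon. The steps already seen are an at least 1.8-fold lower number from compound 1 to compound 2 (0.27 log units; that floor lies within the scatter), an at least 1.8-fold higher number from compound 2 to compound 3 (0.27 log units; that floor lies within the scatter) and a step that the two limits leave unreadable from compound 1 to compound 3; compound 1, whose pyridin-2-yl is also a small heteroaryl on the carbonyl, gives only the limit. The step that the limit leaves unreadable from compound 3 to compound 4 is therefore expected to show nothing beyond the scatter, most likely another limit. Compound 4 is expected to give 150000 nM, between 40000 nM and 600000 nM.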

Compound 4, half-maximal inhibitory concentration: 42700 nM
Estimate against measurement, compound 4: 3.5-fold (0.55 log units) above; low and high end bracket the measured number.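

In this assay, a small heteroaryl on the carbonyl carbon does not by itself leave a compound at the limit: 1,2-oxazol-3-yl gives an at least 2.3-fold lower number from compound 3 to compound 4 (0.36 log units; beyond the scatter) and an at least 2.3-fold lower number from compound 1 to compound 4 (0.36 log units; beyond the scatter). Against 3-chlorophenyl the picture is different, with a 1.2-fold lower number from compound 2 to compound 4 (0.09 log units; within the scatter), so these two groups stand level here. The first two steps are only floors, as each starts from a compound held at a limit: the limit of > 100000 nM in this assay, at which 2 of the 4 values shown sit.

As far as these compounds go, what a 1,3-thiazol-2-yl ring or a phenyl carrying a carboxylic acid would do on this carbonyl carbon remains open. So does whether any group here would give a much lower number.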